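A few compounds are considered here, and "the series" means these few. Any claim that something is new, unique, unknown or untested is made for them only; others in the source may bear on it.

In an ADME assay on CHO cells (Cricetulus griseus) for cytotoxicity, read by MTT assay (a higher number here means that more compound is tolerated, a lower number that less compound is tolerated), compound 3 (`O=C(c1ccnc(Nc2nc3cnc(NC4CCC(F)(F)CC4)cc3[nH]2)c1)N1CCC(F)(F)CC1`) gives > 50000 nM, which is a limit of the assay and not a number. Compound 3 thus stands at the limit of > 50000 nM in this assay, at which 1 of the 3 values shown sits. Compound 1 (`Fc1ccc(Nc2cc3[nH]c(Nc4ccc(N5CCNCC5)cn4)nc3cn2)cc1F`) gives 33000 nM and compound 2 (`O=C(c1ccnc(Nc2nc3cnc(Nc4ccc(F)c(F)c4)cc3[nH]2)c1)N1CCC(F)(F)CC1`) gives 29000 nM, values within the scatter of each other. Compound 4 (`O=C(c1ccnc(Nc2nc3cnc(NC4CC4)cc3[nH]2)c1)N1CCC(F)(F)CC1`) carries cyclopropyl in place of 4,4-difluorocyclohexyl on a nitrogen on an aromatic ring. Among the compounds with values here, the one measured step at this place is an at least 1.7-fold higher number from compound 2 to compound 3 (0.23 log units; that floor lies within the scatter), so no change beyond the scatter is expected in this assay. The expected step is an at least 1.1-fold lower number from compound 3 to compound 4 (0.07 log units; that floor lies within the scatter). For compound 4 the estimate is 42000 nM, with an expected range from 20000 nM to 70000 nM.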

Compound 4, half-maximal cytotoxic concentration: > 50000 nM
Compound 4: a limit, no number (the forecaster's own chance of this, stated with the estimate: 45%); middle value at least 1.1-fold (0.07 log units) away from the limit.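

In this assay, compound 4 gives a limit and not a number, as compound 3 does, so the step between them cannot be read and cyclopropyl and 4,4-difluorocyclohexyl cannot be told apart at this nitrogen. Cyclopropyl in place of 3,4-difluorophenyl gives an at least 1.7-fold higher number from compound 2 to compound 4 (0.23 log units; that floor lies within the scatter), so this smaller non-aromatic ring, like the larger one, shows no change beyond the scatter. The limit is now reached by two non-aromatic rings of different size: the limit of > 50000 nM in this assay, at which 2 of the 4 values shown sit.

From the compounds shown here alone, how far compound 3 and compound 4 lie past that limit stays open. So does what an amine or a longer alkyl chain on this nitrogen would give.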